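The compounds below may be only part of what the source reports. "The series", "measured", "known", "first", "only" and "open" are said of these compounds alone.

Values in a functional assay on RS4-11 cells (Homo sapiens) for inhibition, read by CCK-8 assay, with a stated time of 72 h (a lower number here means a stronger inhibitor, a higher number a weaker inhibitor), for the compounds measured so far:
- compound 1 `CCN(CC)CCCNc1ccc(S(=O)(=O)NC(=O)c2ccc(N3CCN(CC4=C(c5ccc(C(F)(F)F)cc5)CC(C)(C)CC4)CC3)cc2Oc2cnc3[nH]ccc3c2)cc1[N+](=O)[O-]` gives 3 nM
- compound 2 `CN1CCC(CNc2ccc(S(=O)(=O)NC(=O)c3ccc(N4CCN(CC5=C(c6ccc(C(F)(F)F)cc6)CC(C)(C)CC5)CC4)cc3Oc3cnc4[nH]ccc4c3)cc2[N+](=O)[O-])C1` gives 8.3 nM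
- compound 3 `CC(C)C(=O)N1CCC(CNc2ccc(S(=O)(=O)NC(=O)c3ccc(N4CCN(CC5=C(c6ccc(C(F)(F)F)cc6)CC(C)(C)CC5)CC4)cc3Oc3cnc4[nH]ccc4c3)cc2[N+](=O)[O-])CC1` gives 5.3 nM

Compound 2 is separated from only one of the other two compounds. The modest 2.8-fold higher number from compound 1 to compound 2 (0.44 log units; beyond the scatter) sets it apart from compound 1, whereas a 1.6-fold lower number from compound 2 to compound 3 (0.19 log units; within the scatter) leaves it level with compound 3.

Compound 4 `CC1(C)CCC(CN2CCN(c3ccc(C(=O)NS(=O)(=O)c4ccc(OCC5CCOCC5)c([N+](=O)[O-])c4)c(Oc4cnc5[nH]ccc5c4)c3)CC2)=C(c2ccc(C(F)(F)F)cc2)C1` is the next to be measured, and the change that leads to it from compound 2 is (oxan-4-yl)methoxy in place of ((1-methylpyrrolidin-3-yl)methyl)amino on an aromatic carbon on that aromatic carbon. The site lies ortho to a nitro group and para to a large group.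

The measured steps that bear on this are a 2.8-fold higher number from compound 1 to compound 2 (0.44 log units; beyond the scatter) and a 1.6-fold lower number from compound 2 to compound 3 (0.19 log units; within the scatter) together with a 1.8-fold higher number from compound 1 to compound 3 (0.25 log units; within the scatter) as well. All three exchange only the group on a saturated chain carbon, and all are small. Among the measured compounds shown here, no measured compound carries (oxan-4-yl)methoxy, so the loss of the amino link itself is untested and the range must stay wide.

The step expected in this assay is a 1.4-fold higher number from compound 2 to compound 4 (0.16 log units; within the scatter) and thus a slightly higher number, with no step beyond the scatter expected. Compound 4 is estimated at 12 nM (expected range 3.5 nM to 45 nM).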

Compound 4, half-maximal inhibitory concentration: 5.9 nM
Estimate against measurement, compound 4: 2.0-fold (0.31 log units) above; measured number inside the range.
By their numbers in this assay, from the lowest: compounds 1, 3, 4 and 2 (each within the scatter of the next, the first and the last beyond it).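

In this assay, putting (oxan-4-yl)methoxy on the aromatic carbon that lies ortho to a nitro group and para to a large group gives a 1.4-fold lower number from compound 2 to compound 4 (0.15 log units; within the scatter) and a 2.0-fold higher number from compound 1 to compound 4 (0.29 log units; within the scatter), and both steps lie within the scatter. Compounds 1, 2 and 3 all keep the amino link and differ only in the group on a saturated chain carbon, so compound 4 adds the finding that this link can be replaced by an oxygen link, and the ring nitrogen by a ring oxygen, with no step beyond the scatter from compound 2 or from compound 1, even though the entering group has 0 hydrogen-bond donors and the group leaving compound 2 has 1. No measurement at hand accounts for this result.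

The compounds shown change the link atom and the group beyond it together, so the contribution of each remains open; an (oxan-4-yl)methylamino group or a 3-(diethylamino)propoxy group would separate the two. From the compounds shown here alone, how a shorter chain such as a plain methoxy, or a carboxylic acid at the end of the chain, would fare on this aromatic carbon also stays open.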